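A few compounds are considered here, and "the series" means these few. Any claim that something is new, unique, unknown or untested is made for them only; others in the source may bear on it.

Measured compounds in a functional assay on OVCAR-5 cells (Homo sapiens) for inhibition, read by sulforhodamine B assay, with a stated time of 48 h; a higher number here means that more compound is tolerated, a lower number that less compound is tolerated:

Compound 1 `Nc1cc(N)c2nc(-c3ccccc3)c(NCc3ccc(Cl)c(Cl)c3)nc2c1` gives 69200 nM.
Compound 2 `COc1ccc(CNc2nc3cc(N)cc(N)c3nc2-c2ccccc2)cc1` gives only a limit of the assay, < 100000 nM.
Compound 3 `COc1ccc(Sc2nc3cc(N)cc(N)c3nc2-c2ccccc2)cc1` gives only a limit of the assay as well, < 100000 nM.

Compound 3 therefore stands at the limit, where compound 2 also sits; compound 1 alone carries a number. Among the measured compounds shown here, the only step between two compounds differing in a single place, a step that the limit leaves unreadable from compound 1 to compound 2, cannot be read because of the limit of < 100000 nM in this assay, at which 2 of the 3 values shown sit, so the series yields no measured step of known size.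

Compound 4 `Nc1cc(N)c2nc(-c3ccccc3)c(Oc3ccc(F)cc3)nc2c1` has not yet been measured. It differs from compound 3 in one place: 4-fluorophenoxy in place of (4-methoxyphenyl)sulfanyl on an aromatic carbon. For the measured compounds named here, no measured step bears on an exchange of this kind at this position, and the one step recorded is unreadable. With two of three compounds at the limit and compound 1 not far from it, the working expectation is that this change produces no step beyond the scatter in this assay, and that compound 4 will again fall at or near the limit. Compound 4 is estimated at 75000 nM, within 30000 nM to 150000 nM. The estimate amounts to an expected step that the limit leaves unreadable from compound 3 to compound 4.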

Compound 4, concentration lethal to 50% of the cells: < 100000 nM
Compound 4: a limit, no number; the forecaster's own chance of this, stated with the estimate: 55%; the middle value does not contradict the limit.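

In this assay compound 4 gives < 100000 nM, a limit of the assay and not a number. No step can be read between compound 3 and compound 4, because both sit at the same limit: the limit of < 100000 nM in this assay, at which 3 of the 4 values shown sit.

The compounds shown leave open how compound 2, compound 3 and compound 4 rank against one another and against compound 1.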